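Working notes: dichlorophenyl change on compound 3

The source may hold more compounds than are shown below. What is called first, only, known or untested is meant among the compounds shown, and "the series" means these compounds.

- compound 1 `Cc1cc(=O)c2c(O)cc(OCc3ccc([N+](=O)[O-])cc3)c([C@H]3CCN(C)C[C@H]3O)c2o1`: 12%
- compound 2 `CCOC(=O)N1CCN(Cc2c(O)c([C@H]3CCN(C)C[C@H]3O)c3oc(C)cc(=O)c3c2O)CC1`: 4%
- compound 3 `Cc1oc2c([C@H]3CCN(C)C[C@H]3O)c(O)cc(O)c2c(=O)c1C(O)c1cccc(Cl)c1`: 2%

All three values come from a functional assay on MIA PaCa-2 cells (Homo sapiens) for inhibition, read by MTT assay, with a stated time of 48 h, tested at 10 uM; a higher number here means more inhibition of growth at the concentration tested, a lower number less inhibition of growth. In this assay compound 3 gives 2%, which lies within the scatter of both compound 2 and compound 1, so the measured compounds cannot be ranked against one another.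

The next compound, compound 4 `Cc1oc2c([C@H]3CCN(C)C[C@H]3O)c(O)cc(O)c2c(=O)c1C(O)c1c(Cl)cccc1Cl`, carries 2,6-dichlorophenyl in place of 3-chlorophenyl on a saturated chain carbon bound to an aromatic carbon and an oxygen on a saturated carbon.

Going by the values given here, no two measured compounds differ in one place only, so the series offers no measured step by which to size this change. Nothing in the data points to a direction, and no change beyond the scatter is expected in this assay. The expectation rests on compound 3 at 2%. The estimated step, a number 2 percentage points higher from compound 3 to compound 4 (within the scatter), is expected to stay within the scatter. Compound 4 is expected at 4%, with an estimated range of 0% to 14%.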

Compound 4, percent growth inhibition at one concentration: 0%
For compound 4 the middle estimate is 4 percentage points above the measured one, and the stated range covers the measured number.
By their numbers in this assay, from the lowest: compounds 4, 3, 2 and 1 (each within the scatter of the next, the first and the last beyond it).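

In this assay, the series now has its first step in one place, on a saturated chain carbon bound to an aromatic carbon and an oxygen on a saturated carbon: 2,6-dichlorophenyl in place of 3-chlorophenyl gives a number 2 percentage points lower from compound 3 to compound 4 (within the scatter). Going from one chlorine to two on this phenyl ring therefore does not separate the two compounds in this read-out, so this single change gives no measurable handle at this place. No available information bears on the reason for this result.

Going by these compounds, it remains open whether a different kind of group at this place, such as an amine or a carboxylic acid in place of the chlorophenyl ring, would move the number beyond the scatter. On these data alone, the effect of replacing the hydroxy of the (3-chlorophenyl)(hydroxy)methyl group is also open.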